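The compounds below may be only part of what the source reports. "The series", "measured", "known", "first", "only" and "open" are said of these compounds alone.

Measured so far in a functional assay on HepG2 cells (Homo sapiens) for inhibition, read by MTT assay, with a stated time of 72 h; on this read-out higher numbers stand for weaker inhibition and lower numbers for stronger inhibition:

Compound 1, `CN(C(=O)NC(=O)c1cccc(C(F)(F)F)c1)c1nc(C(F)(F)F)c(C(=O)N/N=C/c2cc(C(F)(F)F)cc(C(F)(F)F)c2)s1`, gives 5.38 ug/mL.
Compound 2, `CN(C(=O)NC(=O)c1ccc(C(F)(F)F)cc1)c1nc(C(F)(F)F)c(C(=O)N/N=C/c2cc(C(F)(F)F)cc(C(F)(F)F)c2)s1`, gives 8.35 ug/mL.
Compound 3, `CN(C(=O)NC(=O)c1ccccc1F)c1nc(C(F)(F)F)c(C(=O)N/N=C/c2cccc(C(F)(F)F)c2)s1`, gives 20.3 ug/mL.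

Compound 3 gives the highest number of the three, and its distance to the other two is beyond the scatter. Compound 1 and compound 2 share one core, while compound 3 is built on a different one; the difference between the two cores is not broken down here. Between compound 1 and compound 2 the change is 4-(trifluoromethyl)phenyl in place of 3-(trifluoromethyl)phenyl on a carbonyl carbon, and it made a step of a 1.6-fold higher number from compound 1 to compound 2 (0.19 log units; within the scatter).

Compound 4, `CN(C(=O)NC(=O)c1ccccc1F)c1nc(C(F)(F)F)c(C(=O)N/N=C/c2ccc(C(F)(F)F)cc2)s1`, has not yet been measured. It is made from compound 3 by 4-(trifluoromethyl)phenyl in place of 3-(trifluoromethyl)phenyl on a carbon with a double bond to nitrogen. Among the compounds with values here, this is the same kind of change as the one between compound 1 and compound 2, but not the same: there the 4-(trifluoromethyl)phenyl group entered on a carbonyl carbon whose other neighbour is an amide-type nitrogen, whereas here it enters on a carbon with a double bond to nitrogen.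

For compound 4 a step of a 1.3-fold higher number from compound 3 to compound 4 (0.11 log units; within the scatter) in this assay is expected, of about the same small size as the earlier one, because that earlier step of a 1.6-fold higher number from compound 1 to compound 2 (0.19 log units; within the scatter) stayed within the scatter. This rests on one pair only, so the expectation is loose. Compound 4 is therefore estimated at 26 ug/mL, with a likely range from 12 ug/mL to 55 ug/mL.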

Compound 4, half-maximal inhibitory concentration: 4.56 ug/mL
Compound 4: middle estimate off by 5.7-fold (0.76 log units), on the high side; the measured number lies below the stated range.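

In this assay, 4-(trifluoromethyl)phenyl in place of 3-(trifluoromethyl)phenyl on a carbon with a double bond to nitrogen gave a 4.5-fold lower number from compound 3 to compound 4 (0.65 log units; beyond the scatter), so moving the trifluoromethyl group around this ring clearly mattered here, unlike the earlier swap on a carbonyl carbon. The size and even the direction of this kind of swap therefore did not carry over from one core to the other in this series: the same change on two cores in this assay, a 1.6-fold higher number (0.19 log units; within the scatter) from compound 1 to compound 2 and a 4.5-fold lower number (0.65 log units; beyond the scatter) from compound 3 to compound 4, 6.9-fold (0.84 log units) apart, beyond the scatter of two such steps This does not show why the two steps differ, since they rest on one pair each, and the swap sits at a different place in each pair while the rest of the molecule differs too, so the place of the swap and its surroundings cannot be told apart.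

The compounds shown leave open whether the same swap on the carbon with a double bond to nitrogen would give a similar step on the core of compound 1, and whether the swap on the carbonyl carbon would stay small on the core of compound 3. They also leave open what a chlorine atom, a methoxy group or a nitrile would do in place of trifluoromethyl on the same phenyl ring.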